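Compound 1 to compound 3: hydrogen for methyl

The source may hold more compounds than are shown below. What is called first, only, known or untested is meant among the compounds shown, and "the series" means these compounds.

In a functional assay on HeLa cells (Homo sapiens) for inhibition (a higher number here means a weaker inhibitor, a lower number a stronger inhibitor), compound 1 `Cc1cn(/C=C/C=O)c(=O)[nH]c1=O` gives 100000 nM and compound 2 `Nc1nc(O)c2ncn(/C=C/C=O)c2n1` gives 50000 nM as its value. Compound 1 therefore stands within the usual scatter of compound 2, and the two numbers cannot be told apart.

Compound 3 `O=C/C=C/n1ccc(=O)[nH]c1=O` has not yet been measured. The structural change from compound 1 is a single one hydrogen in place of methyl on an aromatic carbon with hydrogen in place of methyl on an aromatic carbon. For the measured compounds named here, no measured pair shows this change, so the data give no direct guide to its size. In this assay no step beyond the scatter is expected, with at most a slight drift to a lower number. The estimated step of a 1.3-fold lower number from compound 1 to compound 3 (0.10 log units; within the scatter) is expected to stay inside the scatter. In this assay the estimated value for compound 3 is 80000 nM with 35000 nM to 200000 nM as the expected range.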

Compound 3, half-maximal inhibitory concentration: 30000 nM
The estimate for compound 3 lay 2.7-fold (0.43 log units) above the measured number; measured number outside the range, below it.
By their numbers in this assay, from the lowest: compounds 3, 2 and 1 (each within the scatter of the next, the first and the last beyond it).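

In this assay, for the compounds shown here, hydrogen in place of methyl on this aromatic carbon gives a 3.3-fold lower number from compound 1 to compound 3 (0.52 log units; beyond the scatter), the first step to lie beyond the scatter, so the position does respond to the loss of a single carbon. The methyl is not needed for inhibition in this pair, and its removal gives a modest gain rather than a loss. Going by these compounds alone, nothing measured so far accounts for the size or direction of this step.

As far as these compounds go, whether an ethyl group, a chlorine atom or an amine on the same aromatic carbon would shift the number further remains open. This single pair also leaves open whether the same exchange would give a similar step on a different core.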